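The source may hold more compounds than are shown below. What is called first, only, known or untested is meant among the compounds shown, and "the series" means these compounds.

Compound 1, `CC(C)(C)CC[C@H](c1ccc(C(=O)NCc2nn[nH]n2)cc1)N1C(=O)C(c2cncc(Cl)c2)=N[C@]12CC[C@@H](C(C)(C)C)CC2`, was tested in an assay on membranes from liver for displacement of a labelled ligand from Glucagon receptor (Mus musculus), read by scintillation counting, with a stated time of 60 min (on this read-out higher numbers stand for weaker inhibition and lower numbers for stronger inhibition), where compound 1 gives 84 nM. Compound 3, `C[C@H](c1ccc(C(=O)NCCC(=O)O)cc1)N1C(=O)C(c2cccc(F)c2)=N[C@]12CC[C@@H](C(C)(C)C)CC2`, gives 4400 nM in this assay, a clearly higher number that lies beyond the usual scatter. Compound 2, `CC(C)(C)[C@H]1CC[C@]2(CC1)N=C(c1ccc(Cl)cc1)C(=O)N2Cc1ccc(C(=O)NCCC(=O)O)cc1`, reached only > 10000 nM in this assay; that is a limit of the assay and not a number (the limit of > 10000 nM in this assay, at which 1 of the 3 values shown sits). Of the two numbers actually obtained, compound 1 stands lowest, meaning the stronger of the two.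

Compound 4, `CC(C)(C)CC[C@H](c1ccc(C(=O)NCc2nn[nH]n2)cc1)N1C(=O)C(c2ccc(F)cc2)=N[C@]12CC[C@@H](C(C)(C)C)CC2`, has not yet been measured. It differs from compound 1 in one place: 4-fluorophenyl in place of 5-chloropyridin-3-yl on a carbon with a double bond to nitrogen. Among the compounds with values here, no pair of measured compounds differs by exactly this change, so no measured step shows what it does. The 4-fluorophenyl group is expected to land close to where the 5-chloropyridin-3-yl group of compound 1 sits in this assay, with perhaps a slight loss, so the expected step is a 1.8-fold higher number from compound 1 to compound 4 (0.25 log units; within the scatter). Compound 4 is therefore estimated at 150 nM, with a range from 40 nM to 600 nM.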

Compound 4, half-maximal inhibitory concentration: 90 nM
For compound 4 the middle estimate is 1.7-fold (0.22 log units) above the measured one; measured number inside the range.
By their numbers in this assay, from the lowest: compounds 1 and 4 (each within the scatter of the next); then compound 3. At a limit, above all of these: compound 2.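

The step is a 1.1-fold higher number from compound 1 to compound 4 (0.03 log units; within the scatter), so in this assay this change at the carbon with a double bond to nitrogen leaves the two compounds level. At this place, then, a ring of carbon only bearing fluorine serves as well as a ring holding nitrogen and bearing chlorine, and the hydrogen-bond acceptor counted in the 5-chloropyridin-3-yl group is not needed to stay in this range, at least with the rest of compound 1 in place. Nothing measured here explains why the two groups stand level.

From the compounds shown here alone, it remains open how far this tolerance extends, for instance to a plain phenyl ring, a methyl group or an amine at this place. Whether a carboxylic acid chain in place of the tetrazole would behave the same way with 4-fluorophenyl here also stays unresolved.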